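Bromo to nitro on the shared core

A few compounds are considered here, and "the series" means these few. Any claim that something is new, unique, unknown or untested is made for them only; others in the source may bear on it.

In a functional assay on CCRF-CEM cells (Homo sapiens) for antiproliferative activity, read by fluorescence and resazurin assay, with a stated time of 48 h (a lower number here means a stronger inhibitor, a higher number a weaker inhibitor), compound 1 `O=C(N/N=C/c1cc2ccccc2nc1Cl)c1cc2cc(Br)ccc2oc1=O` gives 7450 nM and compound 2 `O=C(N/N=C/c1ccncc1)c1cc2cc(Br)ccc2oc1=O` gives 6340 nM in the same range. Among the measured compounds shown here, compound 2 thus stands within the scatter of compound 1, the only other measured compound. Compound 3 `O=C(N/N=C/c1ccncc1)c1cc2cc([N+](=O)[O-])ccc2oc1=O` carries nitro in place of bromo on an aromatic carbon. For the measured compounds named here, no measured pair tests a change at this place. The estimated step of a 1.0-fold higher number from compound 2 to compound 3 (0.01 log units; within the scatter) is expected to stay within the scatter, with no direction favoured. For compound 3 the estimate is 6500 nM with an expected range from 2500 nM to 17000 nM in this assay.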

Compound 3, half-maximal inhibitory concentration: 13000 nM
The estimate for compound 3 lay 2.0-fold (0.30 log units) below the measured number; measured number inside the range.
By their numbers in this assay, from the lowest: compounds 2, 1 and 3 (each within the scatter of the next, the first and the last beyond it).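

Among the compounds shown here, the step of a 2.1-fold higher number from compound 2 to compound 3 (0.31 log units; beyond the scatter) in this assay is the first reading at this position, and it shows that the position is sensitive to the substituent. With the rest of compound 2 unchanged, bromo gives the lower number of the two groups, although the step is modest. Nothing at hand accounts for this step.

Going by these compounds, whether an amine or a carboxylic acid at this position would stand nearer to bromo or to nitro remains open. Also open, on these data alone, is whether nitro in place of bromo gives a similar step when the rest of the molecule is that of compound 1.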